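Ring contraction on the thiocarbamate of a chromenone

The compounds below may be only part of what the source reports. "The series", "measured", "known", "first", "only" and "open" are said of these compounds alone.

Measured compounds:
compound 1 `O=c1c(CSC(=S)N2CCCCC2)coc2cc(Cl)ccc12`, in a functional assay on LM7 cells (Homo sapiens) for antiproliferative activity, read by MTT assay, with a stated time of 72 h (on this read-out lower numbers stand for stronger inhibition and higher numbers for weaker inhibition), compound 1 gives 850 nM;
compound 3 `CCOC(=O)c1cc(=O)c2cc(CSC(=S)N3CCCC3)ccc2o1`, in this assay compound 3 gives 18000 nM;
compound 2 `O=c1c(CSC(=S)N2CCN(C(c3ccc(F)cc3)c3ccc(F)cc3)CC2)coc2ccccc12`.

In this assay compound 2 gives only a limit, > 25000 nM, so it stands at the limit of > 25000 nM in this assay, at which 1 of the 3 values shown sits, and offers no number. Of the two numbers, compound 1 holds the lower one, and compound 3 sits well beyond the scatter above it. Compound 4 `O=c1c(CSC(=S)N2CCCC2)coc2cc(Cl)ccc12` has not yet been measured. It differs from compound 1 in one place: pyrrolidin-1-yl in place of piperidin-1-yl on a thiocarbonyl carbon. Among the compounds with values here, no pair differing by this change alone has been measured, so the expected step from compound 1 to compound 4 in this assay is estimated as small, within the scatter or slightly weaker: a 1.4-fold higher number from compound 1 to compound 4 (0.15 log units; within the scatter). Compound 4 is therefore expected to give about 1200 nM, between 400 nM and 4000 nM.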

Compound 4, half-maximal inhibitory concentration: 2600 nM
For compound 4 the middle estimate is 2.2-fold (0.34 log units) below the measured one; low and high end bracket the measured number.
By their numbers in this assay, from the lowest: compound 1; then compound 4; then compound 3. At a limit, above all of these: compound 2.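

Replacing piperidin-1-yl with pyrrolidin-1-yl on a thiocarbonyl carbon gives, in this assay, a 3.1-fold higher number from compound 1 to compound 4 (0.49 log units; beyond the scatter), a modest step that goes beyond the scatter. So this position responds to the ring on the thiocarbonyl carbon, and of these two rings piperidin-1-yl gives the lower number. Nothing shown here explains this difference.

Still open, from the compounds shown here alone, is whether a larger ring such as azepane would match compound 1. The same holds for morpholine, a ring with an added oxygen, and for an open-chain diethylamino group.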